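The source may hold more compounds than are shown below. What is called first, only, known or untested is meant among the compounds shown, and "the series" means these compounds.

Measured in a functional assay on MCF7 cells (Homo sapiens) for antiproliferative activity, read by MTT assay, with a stated time of 48 h; a lower number here means a stronger inhibitor, a higher number a weaker inhibitor:

- Compound 1 `COc1ccc(C(=O)c2ccc(OC)c3c2OC(C)(C)C=C3)c(NC(=O)CBr)c1`: 2360 nM
- Compound 2 `COc1ccc(C(=O)c2ccc(OC)c3c2OC(C)(C)C=C3)c(NC(=O)CN)c1`: 410 nM

With only these two results to compare, compound 2 has the lower number at 410 nM, which makes it the stronger inhibitor of the pair. The next compound to consider is compound 3 `CNCC(=O)Nc1cc(OC)ccc1C(=O)c1ccc(OC)c2c1OC(C)(C)C=C2`. It differs from compound 2 by a single small edit: methyl in place of hydrogen on an amine nitrogen.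

Among the compounds with values here, only one measured step bears on this edit: a 5.8-fold lower number from compound 1 to compound 2 (0.76 log units; beyond the scatter). There, amino took the place of bromo on a saturated chain carbon bound to a carbonyl carbon. That step swapped one group for another, whereas here the amino group stays and gains a methyl. Within the data shown here, no measured pair shows what such a methyl does in this assay, so the evidence is indirect. A step smaller than the earlier one is therefore expected, probably none beyond the scatter, with a slight lean towards a higher number.

The estimated step is a 1.2-fold higher number from compound 2 to compound 3 (0.07 log units; within the scatter). For compound 3 the expected value is 480 nM, with an estimated range from 180 nM to 1300 nM.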

Compound 3, half-maximal inhibitory concentration: 820 nM
Compound 3: the middle estimate sits 1.7-fold (0.23 log units) below what was measured; the measured number falls inside the stated range.
By their numbers in this assay, from the lowest: compounds 2 and 3 (each within the scatter of the next); then compound 1.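

In this assay, within the data shown here, the step of a 2.0-fold higher number from compound 2 to compound 3 (0.30 log units; within the scatter) is the first look at a change on the amine nitrogen itself, and it shows that this nitrogen can carry a methyl in place of hydrogen with a difference that repeat measurements could not separate from noise. The step of a 2.9-fold lower number from compound 1 to compound 3 (0.46 log units; beyond the scatter) lies beyond the scatter, so the lower number seen earlier on replacing bromo with amino also appears with methylamino, and neither compound with a nitrogen group here goes against this. Nothing shown here offers a measured explanation for either step.

With a single methyl tested, the compounds shown leave open how much more this nitrogen can carry, for instance whether dimethylamino or ethylamino would stay within the scatter of compound 2 or would move clearly towards compound 1. They also leave open whether a nitrogen is needed at all, which hydroxyl in place of bromo could test, and whether a longer chain carrying the amino group would give a number like those of compound 2 and compound 3.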